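This account rests on a few compounds, and the source may have more. Where it says the series, first, only, none or still open, it means among the compounds named here.

In a functional assay on MCF7 cells (Homo sapiens) for inhibition, read by MTT assay, with a stated time of 72 h (on this read-out higher numbers stand for weaker inhibition and lower numbers for stronger inhibition), the measured compounds stand as follows.

Compound 1 `Cc1ccc(-c2nnc(SCCCN3CCN(c4nc5ccccc5o4)CC3)o2)cc1` gives 60400 nM
Compound 2 `Brc1ccc(-c2nnc(SCCCN3CCN(c4nc5ccccc5o4)CC3)o2)cc1` gives 115000 nM
Compound 3 `CC(C)(C)Oc1ccc(-c2nnc(SCCCN3CCN(c4nc5ccccc5o4)CC3)o2)cc1` is not yet measured

Compound 2 at 115000 nM lies within the scatter of compound 1. The change to compound 3 is tert-butoxy in place of bromo on an aromatic carbon with tert-butoxy in place of bromo on an aromatic carbon. Among the compounds with values here, the one measured step that bears on it is a 1.9-fold higher number from compound 1 to compound 2 (0.28 log units; within the scatter) and no measured compound carries tert-butoxy, so the support is thin. In this assay no step beyond the scatter is expected, and the expected 1.4-fold lower number from compound 2 to compound 3 (0.16 log units; within the scatter) is small. Compound 3 is estimated at 80000 nM with an expected range from 30000 nM to 200000 nM on this read-out.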

Compound 3, half-maximal inhibitory concentration: 94900 nM
For compound 3 the middle estimate is 1.2-fold (0.07 log units) below the measured one; the range from low to high includes it.
By their numbers in this assay, from the lowest: compounds 1, 3 and 2 (each within the scatter of the next).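

In this assay the tert-butoxy change gives a 1.2-fold lower number from compound 2 to compound 3 (0.08 log units; within the scatter) and, against methyl, a 1.6-fold higher number from compound 1 to compound 3 (0.20 log units; within the scatter). On an aromatic carbon para to a large group, methyl, bromo and tert-butoxy therefore do not separate on this read-out, even with 5 heavy atoms entering where bromo brings 1. Nothing available explains this lack of separation. On these data alone, an amine or a carboxylic acid at this position remains open, as does whether any group here can bring the numbers beyond the scatter of these three compounds.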